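Ring-nitrogen substituent change from compound 1 to compound 3

This account rests on a few compounds, and the source may have more. Where it says the series, first, only, none or still open, it means among the compounds named here.

Within the data shown here, compound 1 `O=C(CN1CCN(Cc2cccs2)CC1)C(O)(c1ccccc1)C1CCC1` is one of two compounds measured in a functional assay on ileum for antagonist activity at muscarinic acetylcholine receptor M3 (Cavia porcellus); a higher number here means a weaker inhibitor, a lower number a stronger inhibitor. In this assay compound 1 gives 43.8 nM, the lowest of the two numbers. Among the measured compounds shown here, compound 2 `O=C(CN1CCC(N2CCCC2)CC1)C(O)(c1ccccc1)C1CCCCC1` gives 349 nM, a higher number beyond the scatter; the two structures differ in more than one place, so no single step between them is known. Compound 3 `O=C(CN1CCN(c2ccc([N+](=O)[O-])cc2)CC1)C(O)(c1ccccc1)C1CCC1` carries 4-nitrophenyl in place of (thiophen-2-yl)methyl on an amine nitrogen in a ring. For the measured compounds named here, no measured pair shows this change. In this assay a step of a 3.4-fold higher number from compound 1 to compound 3 (0.53 log units; beyond the scatter) is expected, toward a weaker inhibitor and beyond the scatter. Compound 3 is estimated at 150 nM, within 40 nM to 600 nM.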

Compound 3, antagonist equilibrium constant: > 10000 nM
Compound 3: no number, only a limit; the forecaster's own chance of this, stated with the estimate: 5%; at least 66-fold (1.82 log units) between middle value and limit.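

On the amine nitrogen in the six-membered ring, 4-nitrophenyl in place of (thiophen-2-yl)methyl gives an at least 220-fold higher number from compound 1 to compound 3 (2.35 log units; beyond the scatter) in this assay. Compound 3 has no number, only a limit of the assay: the limit of > 10000 nM in this assay, at which 1 of the 3 values shown sits. Among these compounds, this position can therefore carry the read-out out of the measurable range, which the earlier compounds did not show.

The compounds shown do not separate the loss of the (thiophen-2-yl)methyl group from the arrival of the nitro group. A plain phenyl or a benzyl group on this nitrogen would tell these apart.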